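The source may report more compounds than this note shows. Statements on the series, on what has been measured and on what is new or still open speak of the compounds shown alone.

Working notes on the series in a functional assay on RAW264.7 cells (Mus musculus) for cytotoxicity, read by MTT assay, with a stated time of 24 h; on this read-out lower numbers stand for stronger inhibition and higher numbers for weaker inhibition. Compound 1 `O=S(=O)(O)OCCCCCCCCCC[Se]c1ccccc1` gives > 100000 nM, which is a limit and not a number. Compound 3 `O=S(=O)(O)OCCCCCCCC[Se]c1ccccc1` gives > 100000 nM, again a limit. Both of these compounds carry a selenium atom, and the two results sit together at the limit of > 100000 nM in this assay, at which 2 of the 3 values shown sit. For the measured compounds named here, compound 2 `O=S(=O)(O)OCCCCCCCCCCCC[Te]c1ccccc1`, which carries a tellurium atom, gives 4960 nM, the only true number in this assay so far.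

The next change leads to compound 4 `O=S(=O)(O)OCCCCCCCCCCC[Te]c1ccccc1`. It puts sulfooxy in place of (sulfooxy)methyl on a saturated chain carbon, ten or more bonds along the chain from a tellurium atom.

The nearest measured comparison is a step that the two limits leave unreadable from compound 1 to compound 3. That step shortens the chain in a similar way, but in the selenium compounds, and it gives no size or direction to carry over. The expectation therefore rests on compound 2 at 4960 nM and on the small size of the structural change. No shift beyond the usual scatter is expected, and no direction can be assigned with confidence. The estimated step is a 1.1-fold higher number from compound 2 to compound 4 (0.04 log units; within the scatter). The range is kept wide, since it rests on a single numerical value.

For compound 4 the estimated value is 5500 nM, with an expected range of 2200 nM to 14000 nM.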

Compound 4, half-maximal inhibitory concentration: 7840 nM
Compound 4: middle estimate off by 1.4-fold (0.15 log units), on the low side; measured number inside the range.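

In this assay, the series now has its first readable step: a 1.6-fold higher number from compound 2 to compound 4 (0.20 log units; within the scatter). Placing sulfooxy in place of (sulfooxy)methyl on a saturated chain carbon, ten or more bonds along the chain from a tellurium atom, therefore gives a difference that cannot be separated from repeat scatter, and compound 2 and compound 4 read as equivalent in this assay. The comparable step among the selenium compounds cannot be read, because compound 1 and compound 3 both give a limit and not a number: the limit of > 100000 nM in this assay, at which 2 of the 4 values shown sit.

Still open is whether the tellurium atom itself accounts for the numerical values, since the compounds shown offer no selenium and tellurium pair that differs in that atom alone. Also open, from the compounds shown here alone, is whether this flat reading extends beyond this narrow chain change, for example to a much shorter or much longer chain, or to a carboxylic acid or an amine in place of sulfooxy.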